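Removing One Methoxy from a Chloro-diene Nitrile Ketone

The source may hold more compounds than are shown below. What is called first, only, known or untested is meant among the compounds shown, and "the series" means these compounds.

Compound 1 `COc1ccc2[nH]cc(C(=O)/C(C#N)=C/C=C(\Cl)c3ccc(OC)c(OC)c3)c2c1`: in a functional assay on MCF7 cells (Homo sapiens) for cytotoxicity, read by sulforhodamine B assay, with a stated time of 48 h (a higher number here means a weaker inhibitor of growth, a lower number a stronger inhibitor of growth), compound 1 gives > 100000 nM, which is a limit of the assay.
Compound 2 `COc1cc(/C(Cl)=C/C=C(\C#N)C(=O)c2c[nH]c3ccc(Br)cc23)cc(OC)c1OC`: in this assay compound 2 gives 96500 nM.

Among the compounds with values here, compound 2 thus holds the only numerical value shown; the other value is the limit of > 100000 nM in this assay, at which 1 of the 2 values shown sits. Compound 3 `COc1ccc(/C(Cl)=C/C=C(\C#N)C(=O)c2c[nH]c3ccc(Br)cc23)cc1OC` differs from compound 2 by hydrogen in place of methoxy on an aromatic carbon. Within the data shown here, no measured pair isolates this change, so the step from compound 2 to compound 3 in this assay is expected to be none beyond the scatter, as a 1.0-fold higher number from compound 2 to compound 3 (0.02 log units; within the scatter). Compound 3 is therefore estimated to give 100000 nM in this assay, expected between 40000 nM and 250000 nM.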

Compound 3, concentration for total growth inhibition: > 100000 nM
Compound 3 ended at the assay's limit; the forecaster's own chance of this, stated with the estimate: 45%; the middle value sits exactly at the limit.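

Compound 3 gives a limit of the assay rather than a number, and so it joins the ceiling of the set: the limit of > 100000 nM in this assay, at which 2 of the 3 values shown sit. Hydrogen in place of methoxy on this aromatic carbon gives an at least 1.0-fold higher number from compound 2 to compound 3 (0.01 log units; that floor lies within the scatter), so the change brings no gain in growth inhibition. The step with bromo in place of methoxy cannot be read, as both of its values are limits.

As far as these compounds go, how far the true step from methoxy to hydrogen runs remains open. So does whether a hydroxyl or an amine on this carbon would give a number clear of the limit.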